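The source may hold more compounds than are shown below. What is called first, only, known or untested is meant among the compounds shown, and "the series" means these compounds.

The study opens with two amides built on a shared core, compound 1 `O=C(NS(=O)(=O)c1ccc(NC(=O)c2ccc(Cl)cc2Cl)cc1)c1ccccc1` and compound 2 `Cc1cc(Cl)ccc1C(=O)Nc1ccc(S(=O)(=O)Nc2ccccc2)cc1`, examined in a functional assay on HEK293 cells for agonist activity at probable G-protein coupled receptor 27 (Homo sapiens), read by a luciferase reporter and beta-arrestin recruitment, with a stated time of 10 min; a higher number here means a larger maximal response, a lower number a smaller maximal response. For compound 1 the outcome is "not determined" (no result reported), so no number stands for it. In this assay, going by the values given here, compound 2 gives 123%, and this is the only number known here; the one further entry carries no single number, so compound 2 stands alone and cannot be set against anything. The next step leads to compound 3 `Cc1cc(Br)ccc1C(=O)Nc1ccc(S(=O)(=O)Nc2ccccc2)cc1`. The change from compound 2 to compound 3 is bromo in place of chloro on an aromatic carbon. Chloro leaves and bromo enters, on an aromatic carbon of a six-membered aromatic ring of carbon only, meta to a methyl group and para to a large group; cut one bond further out, 4-chloro-2-methylphenyl becomes 4-bromo-2-methylphenyl. Among the compounds with values here, no pair of measured compounds shows what such a swap does, so the expected step in this assay is small, with no direction beyond the usual scatter. For compound 3 the estimate is 120%, with a range from 95% to 145%. The expected step is then a number 3 percentage points lower from compound 2 to compound 3 (within the scatter).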

Compound 3, largest response reached (Emax), in percent of the reference or control that the assay uses: 103%
For compound 3 the middle estimate is 17 percentage points above the measured one; the measured number falls inside the stated range.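

In this assay, bromo in place of chloro on this aromatic carbon, para to a large group, gives a number 20 percentage points lower from compound 2 to compound 3 (beyond the scatter). This first measured step shows that the position is sensitive to which halogen it carries: one heavy atom replaces one heavy atom, neither has hydrogen-bond donors or acceptors, neither has a net charge, and still the maximal response shifts by more than the usual scatter. No measurement is at hand that would explain why the two halogens differ here.

As far as these compounds go, a single step cannot set a trend, so it remains open how the maximal response would respond to other groups at this carbon, such as fluoro, methoxy, or a carboxylic acid. From the compounds shown here alone, it is also open whether the swap from chloro to bromo would give a step of similar size and direction if an ethyl chain or a methoxy group stood in place of the methyl group.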